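The source may hold more compounds than are shown below. What is called first, only, known or untested is meant among the compounds shown, and "the series" means these compounds.

Compound 2 `CC1(C)CC(NC(=O)NCc2ccccc2)c2cc(Cl)ccc2O1` gives 66000 nM in a functional assay on U-373MG ATCC cells (Homo sapiens) for inhibition, read by MTT assay, with a stated time of 72 h (on this read-out higher numbers stand for weaker inhibition and lower numbers for stronger inhibition), the highest of the two numbers in hand; compound 1 `CC1(C)CC(NC(=O)NCc2ccccc2)c2cc(Br)ccc2O1` gives 27000 nM. Going by the values given here, the only measured step, a 2.4-fold higher number from compound 1 to compound 2 (0.39 log units; beyond the scatter), concerns the halogen on an aromatic carbon and does not touch the group on the amide-type nitrogen. Compound 3 `CCNC(=O)NC1CC(C)(C)Oc2ccc(Cl)cc21` differs from compound 2 by methyl in place of phenyl on a saturated chain carbon bound to an amide-type nitrogen. Among the compounds with values here, no measured step bears on this change, so neither size nor direction of the step in this assay can be anchored, and a wide range is warranted. For compound 3 the expected step is a 1.2-fold higher number from compound 2 to compound 3 (0.08 log units; within the scatter), giving an estimated 80000 nM with a range of 25000 nM to 250000 nM.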

Compound 3, half-maximal inhibitory concentration: > 100000 nM
Compound 3: a limit, no number (the forecaster's own chance of this, stated with the estimate: 30%); middle value at least 1.2-fold (0.09 log units) away from the limit.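

Going by these compounds alone, this is the first reading at the group on the amide-type nitrogen, since the earlier step touched only the halogen. Methyl in place of phenyl on a saturated chain carbon bound to an amide-type nitrogen gives an at least 1.5-fold higher number from compound 2 to compound 3 (0.18 log units; that floor lies within the scatter), so the direction is suggested, but the floor does not establish a change beyond the scatter. Compound 3 gives > 100000 nM in this assay, a limit and not a number: the limit of > 100000 nM in this assay, at which 1 of the 3 values shown sits.

As far as these compounds go, the true size of this step stays open. Also open, from the compounds shown here alone, is how a longer chain, an amine or a carboxylic acid in place of phenyl would read in this assay.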